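Pyridazinone amides: aryl swap on the ring nitrogen

The source may report more compounds than this note shows. Statements on the series, on what has been measured and on what is new or still open speak of the compounds shown alone.

Measured compounds:
compound 1, `CNC(=O)c1cc(Oc2ccc(NC(=O)c3nn(-c4ccccc4C(F)(F)F)c(=O)cc3C)cc2F)ccn1`, in a functional assay on A549 cells (Homo sapiens) for cytotoxicity, read by MTT assay, with a stated time of 72 h; a higher number here means a weaker inhibitor, a lower number a stronger inhibitor: > 40000 nM
compound 2, `CNC(=O)c1cc(Oc2ccc(NC(=O)c3nn(-c4ccc(Br)cc4F)c(=O)cc3C)cc2F)ccn1`, in this assay: 7930 nM
compound 3, `Cc1cc(=O)n(-c2ccccc2C(F)(F)F)nc1C(=O)Nc1ccc(Oc2ncnc3ccsc23)cc1`, in this assay: 8850 nM

The value of compound 1 is a limit of this assay, not a number. Within the data shown here, the single measured step, an at least 5.0-fold lower number from compound 1 to compound 2 (0.70 log units; beyond the scatter), is therefore known only as a lower bound on its size, because of the limit of > 40000 nM in this assay, at which 1 of the 3 values shown sits. The change behind it is 4-bromo-2-fluorophenyl in place of 2-(trifluoromethyl)phenyl on an aromatic nitrogen.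

Compound 3 carries a different core from compound 1; the difference between the two cores is not broken down here. In this assay compound 3 and compound 2 sit within the scatter of each other, so no order between them is claimed.

Compound 4, `Cc1cc(=O)n(-c2ccc(Br)cc2F)nc1C(=O)Nc1ccc(Oc2ncnc3ccsc23)cc1`, has not been measured. It differs from compound 3 by 4-bromo-2-fluorophenyl in place of 2-(trifluoromethyl)phenyl on an aromatic nitrogen, the same change that separates compound 1 from compound 2. On that one measured step, an at least 5.0-fold lower number from compound 1 to compound 2 (0.70 log units; beyond the scatter), the expectation is that the same change on the core of compound 3 moves the number in the same direction, estimated as a 4.9-fold lower number from compound 3 to compound 4 (0.69 log units; beyond the scatter). The size rests on a single pair whose starting point is a limit, so the lower bound could understate the true step. For compound 4 the estimated value in this assay is 1800 nM, expected between 500 nM and 6500 nM.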

Compound 4, half-maximal inhibitory concentration: 7930 nM
Estimate against measurement, compound 4: 4.4-fold (0.64 log units) below; measured number above the stated range.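

On the core of compound 3, 4-bromo-2-fluorophenyl in place of 2-(trifluoromethyl)phenyl gives a 1.1-fold lower number from compound 3 to compound 4 (0.05 log units; within the scatter) in this assay, so the step seen on the core of compound 1 is not reproduced here. The size of this change therefore depends on the core it is placed on, at least for these two cores: the same change on two cores in this assay, an at least 5.0-fold lower number (0.70 log units; beyond the scatter) from compound 1 to compound 2 and a 1.1-fold lower number (0.05 log units; within the scatter) from compound 3 to compound 4, at least 4.5-fold (0.65 log units) apart, beyond the scatter of two such steps

Compound 1 gives > 40000 nM, a limit and not a number, so the full size of the step on its core stays unknown, and two pairs neither explain the difference between the cores nor predict the step on a third core: the limit of > 40000 nM in this assay, at which 1 of the 4 values shown sits.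

Going by these compounds, the swap replaces a whole aryl group, so the separate contributions of the bromine, the fluorine and the loss of trifluoromethyl remain open, as would be read from singly substituted phenyl groups on the same ring nitrogen on both cores. Also open, on these data alone, is how either core responds when that nitrogen carries a phenyl group bearing an amine or a carboxylic acid, or a simple alkyl chain in place of the aryl ring.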